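The compounds below may be only part of what the source reports. "The series", "measured", "known", "first", "only" and "open" are said of these compounds alone.

Compound 1, `C[C@@H](C(=O)O)c1nn(Cc2cn3cc(OCC4CC4)c(Cl)cc3n2)c2ccccc2c1=O`, gives 3180 nM in a functional assay on HFL1 cells for antagonist activity at sphingosine 1-phosphate receptor 2 (Homo sapiens), read by ELISA, with a stated time of 24 h, in the presence of a further agent that is not named here; on this read-out lower numbers stand for stronger inhibition and higher numbers for weaker inhibition; of the two measured compounds it has the higher number, since compound 2, `O=C(O)Cn1nc(Cn2cc3cc(OCC4CC4)c(Cl)cc3n2)c2ccccc2c1=O`, gives 647 nM in this assay. Compound 3, `O=C(O)Cc1nn(Cc2cn3cc(OCC4CC4)c(Cl)cc3n2)c2ccccc2c1=O`, differs from compound 1 by hydrogen in place of methyl on a saturated chain carbon bound to an aromatic carbon and a carbonyl carbon. Among the measured compounds shown here, no single-point step between measured compounds is available, so the expectation rests on the direction suggested by compound 2, whose carboxymethyl chain comes with 647 nM. For compound 3 a modest step toward a lower number is expected, a 1.8-fold lower number from compound 1 to compound 3 (0.25 log units; within the scatter), though it may not exceed the scatter. Compound 3 is estimated at 1800 nM, within 600 nM to 5000 nM.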

Compound 3, half-maximal inhibitory concentration: 60 nM
Estimate against measurement, compound 3: 30-fold (1.48 log units) above; the measured number lies below the stated range.
By their numbers in this assay, from the lowest: compound 3; then compound 2; then compound 1.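

Among the compounds shown here, the step of a 53-fold lower number from compound 1 to compound 3 (1.72 log units; beyond the scatter) in this assay is the first comparison here that isolates a single place: the saturated chain carbon bound to an aromatic carbon and a carbonyl carbon. It shows that the change from 1-carboxyethyl to carboxymethyl, with the loss of one carbon and the core unchanged, is enough to produce a large change in this read-out. Nothing available accounts for the size of this step.

The compounds shown leave open how an ethyl, a hydroxyl or a fluorine at this carbon would read. They also leave open what an amide in place of the carboxylic acid would do.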